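Notes on the series: chloro in place of nitro

The source may hold more compounds than are shown below. What is called first, only, known or untested is meant among the compounds shown, and "the series" means these compounds.

In a functional assay on PC-3 cells (Homo sapiens) for inhibition, read by MTT assay, with a stated time of 48 h, tested at 10 uM (a lower number here means less inhibition of growth, a higher number more inhibition of growth at the concentration tested), compound 1 (`Cc1cc(=O)c2c(O)c(CN3CCCC3C(=O)O)c(O)c([C@H]3CCN(C)C[C@H]3O)c2o1`) gives 0% and compound 2 (`Cc1oc2c([C@H]3CCN(C)C[C@H]3O)c(O)cc(O)c2c(=O)c1C(O)c1ccc([N+](=O)[O-])cc1`) gives 24% as the higher of the two numbers, with a gap beyond the scatter. Compound 3 (`Cc1oc2c([C@H]3CCN(C)C[C@H]3O)c(O)cc(O)c2c(=O)c1C(O)c1ccc(Cl)cc1`) is still unmeasured and differs from compound 2 in one place: chloro in place of nitro on an aromatic carbon, para to a large group (chloro in place of nitro on an aromatic carbon). The 4-nitrophenyl thus becomes 4-chlorophenyl. For the measured compounds named here, no measured pair shows a change at this place, and the data give no direction for it. The expectation rests on compound 2 at 24% as the only anchor. Expected is a number 4 percentage points higher from compound 2 to compound 3 (within the scatter) as a small move that stays within the scatter. For compound 3 the estimated value is 28% (expected range 10% to 48%).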

Compound 3, percent growth inhibition at one concentration: 41%
Beside the measured number, compound 3's estimate is 13 percentage points below it, within the range that was stated.
By their numbers in this assay, from the lowest: compound 1; then compound 2; then compound 3.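

In this assay, chloro in place of nitro on this aromatic carbon, para to a large group, gives a number 17 percentage points higher from compound 2 to compound 3 (beyond the scatter), so the substituent at this place affects the read-out. Nitro is not required for growth inhibition in this pair: the 4-chlorophenyl of compound 3 retains that inhibition, and to a greater degree than the 4-nitrophenyl of compound 2. Nothing at hand accounts for the size or direction of this step.

One step gives a direction for this single exchange and no trend across substituents. On these data alone, whether fluoro, bromo, methoxy or an amine on the same carbon would fall nearer to chloro or to nitro remains open, as does whether the step would hold at other concentrations.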